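A few compounds are considered here, and "the series" means these few. Any claim that something is new, unique, unknown or untested is made for them only; others in the source may bear on it.

Compound 2 `Cc1c(C)c2c(c(C)c1OC(=O)C(N)C(C)C)CC(CCn1ccc(=O)c(O)c1C)O2` has been tested in an ADME assay for solubility; on this read-out lower numbers stand for lower solubility and higher numbers for higher solubility. In this assay compound 2 gives > 20000 ug/mL, which is a limit of the assay rather than a measured number. Compound 1 `CNCC(=O)Oc1c(C)c(C)c2c(c1C)CC(CCn1ccc(=O)c(O)c1C)O2` carries a (methylamino)methyl group on a carbonyl carbon instead. In this assay compound 1 gives > 20000 ug/mL, again a limit of the assay. The step that the two limits leave unreadable from compound 1 to compound 2 cannot be read, since (the limit of > 20000 ug/mL in this assay, at which 2 of the 2 values shown sit). Compound 3 `Cc1c(C)c2c(c(C)c1OC(=O)CN(C)C)CC(CCn1ccc(=O)c(O)c1C)O2` is not yet measured; it differs from compound 2 by (dimethylamino)methyl in place of 1-amino-2-methylpropyl on a carbonyl carbon. For the measured compounds named here, both measured compounds sit at the limit, so no measured step gives a size for this change. For compound 3 the expected step of a number no higher from compound 2 to compound 3 (the limit leaves the size open) is none beyond the scatter, with the result most likely again reported as a limit. Compound 3 is therefore estimated at 20000 ug/mL, within a range from 10000 ug/mL to 40000 ug/mL.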

Compound 3, solubility: > 20000 ug/mL
Compound 3 was reported as a limit (the forecaster's own chance of this, stated with the estimate: 80%); the middle value sits exactly at the limit.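

For the compounds shown here, no step among compound 1, compound 2 and compound 3 can be read in this assay, since each is reported only as a limit: the limit of > 20000 ug/mL in this assay, at which 3 of the 3 values shown sit. The compounds shown leave open the actual solubility of each compound, and whether the groups on the carbonyl carbon change it at all.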